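Flipping Two Ring Stereocentres in a Liver Microsome Assay

The source may report more compounds than this note shows. Statements on the series, on what has been measured and on what is new or still open speak of the compounds shown alone.

Measured so far in an ADME assay (liver) for metabolic stability, with Liver microsome (Rattus norvegicus) as the target, using microsomes, with a stated time of 30 min; on this read-out higher numbers stand for a more stable compound and lower numbers for a less stable compound:
Compound 1, `COC(=O)N[C@H](C(=O)N1CCC[C@H]1C(=O)Nc1ccc([C@H]2CC[C@H](c3ccc(NC(=O)[C@@H]4CCCN4C(=O)[C@@H](NC(=O)OC)C(C)C)cc3)N2c2ccc(C(F)(F)F)cc2)cc1)C(C)C`, gives 58%.
Compound 2, `COC(=O)N[C@H](C(=O)N1CCC[C@H]1C(=O)Nc1ccc([C@@H]2CC[C@@H](c3ccc(NC(=O)[C@@H]4CCCN4C(=O)[C@@H](NC(=O)OC)C(C)C)cc3)N2c2ccc(F)cc2)cc1)C(C)C`, gives 49%.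
Compound 3, `COC(=O)N[C@H](C(=O)N1CCC[C@H]1C(=O)Nc1ccc([C@@H]2CC[C@@H](c3ccc(NC(=O)[C@@H]4CCCN4C(=O)[C@@H](NC(=O)OC)[C@H]4CCOC4)cc3)N2c2ccc(F)cc2)cc1)[C@H]1CCOC1`, gives 42%.

Compound 3 gives the lowest of the three numbers in this assay; its gap to compound 2 lies within the usual scatter, while its gap to compound 1 lies beyond it. Compound 4, `COC(=O)N[C@H](C(=O)N1CCC[C@H]1C(=O)Nc1ccc([C@H]2CC[C@H](c3ccc(NC(=O)[C@@H]4CCCN4C(=O)[C@@H](NC(=O)OC)[C@H]4CCOC4)cc3)N2c2ccc(F)cc2)cc1)[C@H]1CCOC1`, has not yet been measured. Its structure differs from compound 3 as follows: the two compounds have the same atoms and bonds and differ only in configuration as drawn: 2 of 8 stereo elements differ; a stereocentre at a saturated ring carbon is drawn S in compound 3 and R in compound 4; a stereocentre at a saturated ring carbon is drawn S in compound 3 and R in compound 4. Within the data shown here, no step between measured compounds isolates such a change in configuration, so nothing measured here shows how far it moves this assay. The expectation for compound 4 is therefore a small step in either direction, most likely none beyond the scatter. Compound 4 is estimated at 45%, within a range from 30% to 60%, an expected step of a number 3 percentage points higher from compound 3 to compound 4 (within the scatter).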

Compound 4, percent of the compound remaining: 46%
For compound 4 the middle estimate is 1 percentage points below the measured one, and the stated range covers the measured number.
By their numbers in this assay, from the lowest: compounds 3, 4, 2 and 1 (each within the scatter of the next, the first and the last beyond it).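

Inverting the two saturated ring carbons gives the first direct reading of configuration in this assay, and the step is a number 4 percentage points higher from compound 3 to compound 4 (within the scatter). At this position and in this pair, the inversion therefore leaves the percentage of compound remaining unchanged within the usual scatter. Only one kind of difference exists between these two structures: the fact that compounds 3 and 4 differ only in the configuration as drawn

A single pair supports no general rule about configuration across the series. It also leaves open whether the inversion would have an equally small effect with an amine or a carboxylic acid in place of the fluorine.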